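This account rests on a few compounds, and the source may have more. Where it says the series, first, only, none or still open, it means among the compounds named here.

Measured so far:
compound 1 `O=C(/C=C/c1ccc(OCc2cn(Cc3ccccc3)nn2)cc1)c1ccc([N+](=O)[O-])cc1`, in a functional assay on MIA PaCa-2 cells (Homo sapiens) for inhibition, read by MTT assay, with a stated time of 48 h, tested at 10 uM; on this read-out lower numbers stand for less inhibition of growth and higher numbers for more inhibition of growth at the one concentration tested: "not active" (no number reported)
compound 2 `O=C(/C=C/c1ccc(OCc2cn(Cc3cccc(Br)c3)nn2)cc1)c1ccc([N+](=O)[O-])cc1`, in this assay: 21%

Among the measured compounds shown here, compound 2 holds the only number recorded in this assay; compound 1 stands there as "not active" (no number reported) without a figure, so no step between measured compounds can be sized. Compound 3 `O=C(/C=C/c1ccc(OCc2cn(Cc3ccccc3F)nn2)cc1)c1ccc([N+](=O)[O-])cc1` differs from compound 2 in one place: 2-fluorophenyl in place of 3-bromophenyl on a saturated chain carbon bound to an aromatic nitrogen. For the measured compounds named here, with no measured step to lean on, only a small shift is expected from compound 2 to compound 3, a number 8 percentage points lower from compound 2 to compound 3 (within the scatter), likely within the scatter and if anything downward, since compound 1 gives "not active" (no number reported). Compound 3 is estimated at 13%, within 0% to 30%.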

Compound 3, percent growth inhibition at one concentration: 22%
Beside the measured number, compound 3's estimate is 9 percentage points below it, and the stated range covers the measured number.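

In this assay, 2-fluorophenyl in place of 3-bromophenyl gives a number 1 percentage points higher from compound 2 to compound 3 (within the scatter), so at this place on a saturated chain carbon bound to an aromatic nitrogen, the two groups cannot be told apart. Among the compounds shown here, this is the first step that can be sized. Nothing available explains this result.

Steps to compound 1 cannot be read, as it carries no number. Still open, as far as these compounds go, is how an amine or a carboxylic acid on the phenyl ring, or a longer chain in place of the benzyl link, would read at this place.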